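The source may report more compounds than this note shows. Statements on the series, on what has been measured and on what is new or still open speak of the compounds shown alone.

Among the compounds with values here, compound 2 `NS(=O)(=O)Oc1ccc2c(c1)CN(C(=O)c1ccc(N3CCCCC3)cc1)CC2` stands highest of the two numbers so far in an assay on HEK293 cells for inhibition of Steryl-sulfatase (Homo sapiens), tested at 0.1 uM; a higher number here means a stronger effect of the compound at the concentration tested, a lower number a weaker effect: compound 2 gives 11.5%, whereas compound 1 `CN(C)CCN(CCN(C)C)c1cccc(C(=O)N2CCc3ccc(OS(N)(=O)=O)cc3C2)c1` gives 0%, a gap beyond the usual scatter. Compound 3 `CCCN(CCC)c1ccc(C(=O)N2CCc3ccc(OS(N)(=O)=O)cc3C2)cc1` has not been measured. It differs from compound 2 in one place, (dipropylamino in place of piperidin-1-yl on an aromatic carbon). Within the data shown here, no pair of measured compounds isolates this change, so the expected step in this assay is small, with no clear direction, and within the scatter. The step expected is a number 0.5 percentage points higher from compound 2 to compound 3 (within the scatter). For compound 3 the estimated inhibition is 12%, expected to fall between 0% and 28%.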

Compound 3, a percentage reported as inhibition, at one concentration (the size of the read-out at that concentration, not a potency): 36.6%
Compound 3: middle estimate off by 24.6 percentage points, on the low side; measured number above the stated range.
By their numbers in this assay, from the lowest: compound 1; then compound 2; then compound 3.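

Within the data shown here, replacing the piperidin-1-yl ring with dipropylamino on this aromatic carbon, para to a large group, is the first single change isolated at this position: in this assay the step is a number 25.1 percentage points higher from compound 2 to compound 3 (beyond the scatter) and it shows that the ring and the open chains are not interchangeable here. The hydrogen-bond counts and the absence of net charge stay the same across the change. No measurement on hand explains the step.

Going by these compounds, whether the gain follows from opening the ring or from chain length remains open. Diethylamino or dibutylamino at this position would separate the two.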